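The source may report more compounds than this note shows. Statements on the series, on what has been measured and on what is new or still open speak of the compounds shown alone.

Compound 1 `O=C1O/C(=C\Cn2ncc(=O)[nH]c2=O)C(OCc2ccccc2)=C1OCc1ccccc1`: 24600 nM
Compound 2 `Nc1ccn(C[C@H](O)[C@H]2OC(=O)C(OCc3ccccc3)=C2OCc2ccccc2)c(=O)n1`: 53900 nM

In an ADME assay on WI-38 cells (Homo sapiens) for inhibition, read by MTT assay, with a stated time of 72 h (on this read-out lower numbers stand for stronger inhibition and higher numbers for weaker inhibition), compound 1 gives 24600 nM, the lower of the two numbers recorded so far, while compound 2 gives 53900 nM, a weaker result that lies beyond the usual scatter. Compound 3 `O=C1O/C(=C\Cn2c(=O)[nH]c(=O)[nH]c2=O)C(OCc2ccccc2)=C1OCc1ccccc1` shares the core of compound 1 and differs from it only at one point: a group of 9 heavy atoms (3 carbon, 3 nitrogen, 3 oxygen; one six-membered aromatic ring with 3 hetero atoms) in place of a group of 8 heavy atoms (3 carbon, 3 nitrogen, 2 oxygen; one six-membered aromatic ring with 3 hetero atoms), on a saturated chain carbon bound to a double-bonded chain carbon. Within the data shown here, no measured pair shows this kind of change, so the size of the step is open. With so little to go on, compound 3 is expected to stay close to compound 1, with a step of a 1.2-fold higher number from compound 1 to compound 3 (0.09 log units; within the scatter) no larger than the scatter, giving an estimated 30000 nM in this assay, somewhere between 10000 nM and 90000 nM.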

Compound 3, half-maximal inhibitory concentration: 10 nM
For compound 3 the middle estimate is 3000-fold (3.48 log units) above the measured one, outside the stated range (below it).
By their numbers in this assay, from the lowest: compound 3; then compound 1; then compound 2.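

In this assay the group of 9 heavy atoms in place of the group of 8 heavy atoms brings a 2500-fold lower number from compound 1 to compound 3 (3.39 log units; beyond the scatter) on an unchanged core. At this place, on a saturated chain carbon bound to a double-bonded chain carbon, a change of one heavy atom between two six-membered aromatic rings with 3 hetero atoms can therefore decide the result. Nothing measured here explains the size of this step.

From the compounds shown here alone, whether an amine or a carboxylic acid at this place would keep so low a number remains open. So does the effect of a longer chain carrying the ring of compound 3.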